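Changing the hydrazone arm of a thiosemicarbazone

This account rests on a few compounds, and the source may have more. Where it says the series, first, only, none or still open, it means among the compounds named here.

Compound 1 `COc1ccc(/C=N\NC(=S)NC(C)(C)CCC[C@](C)(O)[C@@H]2CC=C(C)CC2)cc1` gives 15800 nM in a functional assay on OVCAR-3 cells (Homo sapiens) for cytotoxicity, read by sulforhodamine B assay (on this read-out lower numbers stand for stronger inhibition of growth and higher numbers for weaker inhibition of growth), the lowest number among those shown; its nearest neighbour is compound 3 `CC1=CC[C@@H]([C@@](C)(O)CCCC(C)(C)NC(=S)N/N=C\c2cccc([N+](=O)[O-])c2)CC1`, which in this assay gives 40800 nM. Compound 2 `CC1=CC[C@@H]([C@@](C)(O)CCCC(C)(C)NC(=S)N/N=C\c2ccc(N(C)C)cc2)CC1` reaches only an assay limit of > 100000 nM in this assay, so the limit of > 100000 nM in this assay, at which 1 of the 3 values shown sits, leaves it without a number. Compound 4 `CC1=CC[C@@H]([C@@](C)(O)CCCC(C)(C)NC(=S)N/N=C(/C)c2ccccc2)CC1` differs from compound 1 by a group of 9 heavy atoms (8 carbon, 1 nitrogen; one six-membered aromatic ring of carbon only) in place of a group of 10 heavy atoms (8 carbon, 1 nitrogen, 1 oxygen; one six-membered aromatic ring of carbon only), on an amide-type nitrogen. Both measured changes at this end of the molecule raised the number: an at least 6.3-fold higher number from compound 1 to compound 2 (0.80 log units; beyond the scatter) and a 2.6-fold higher number from compound 1 to compound 3 (0.41 log units; beyond the scatter), while an at least 2.4-fold lower number from compound 2 to compound 3 (0.38 log units; beyond the scatter). Among the measured compounds shown here, neither change matches the one leading to compound 4, so only a modest rise in this assay is expected, a 1.9-fold higher number from compound 1 to compound 4 (0.28 log units; within the scatter). Compound 4 is therefore estimated at 30000 nM, with a range from 8000 nM to 120000 nM.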

Compound 4, concentration for total growth inhibition: 59500 nM
The estimate for compound 4 lay 2.0-fold (0.30 log units) below the measured number; measured number inside the range.
By their numbers in this assay, from the lowest: compound 1; then compounds 3 and 4 (each within the scatter of the next). At a limit, above all of these: compound 2.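

In this assay, a third kind of group on the amide-type nitrogen, this one without oxygen, also weakens growth inhibition, with a 3.8-fold higher number from compound 1 to compound 4 (0.58 log units; beyond the scatter). Every replacement shown for the group in compound 1 therefore gives a higher number, and none improves on it. Nothing measured here accounts for this rise.

The compounds shown leave open whether a hydroxyl or a fluorine on the aromatic ring could give a number lower than that of compound 1. They also leave open which part of the group that enters drives the step.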